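Ring-nitrogen acyl group and growth inhibition in the series

The source may hold more compounds than are shown below. What is called first, only, known or untested is meant among the compounds shown, and "the series" means these compounds.

Three compounds of the shared core have numbers in a functional assay on NCI-H23 cells (Homo sapiens) for cytotoxicity, read by sulforhodamine B assay, with a stated time of 72 h; on this read-out lower numbers stand for stronger inhibition of growth and higher numbers for weaker inhibition of growth. Compound 1 `O=C(Nc1ccccc1O)C1CCc2ccccc2N1C(=O)c1ccccc1Cl` gives 46900 nM, compound 2 `O=C(Nc1ccccc1C(F)(F)F)C1CCc2ccccc2N1` gives 56800 nM, and compound 3 `O=C(Nc1ccccc1O)C1CCc2ccccc2N1C(=O)c1ccccc1` gives 3490 nM. Going by the values given here, compound 3 stands lowest of the three; the one measured step that reaches it, a 13-fold lower number from compound 1 to compound 3 (1.13 log units; beyond the scatter), shows that a change on the benzoyl group alone moved this assay by a large amount. Compound 4 `O=C(Nc1ccccc1O)C1CCc2ccccc2N1` differs from compound 3 by hydrogen in place of benzoyl on a nitrogen on an aromatic ring in a ring. Among the compounds with values here, no measured step removes the benzoyl group while the hydroxy partner is held fixed. Within the data shown here, compound 2, the only measured compound with a free ring nitrogen, carries a trifluoromethyl partner instead and gives a number that lies far above that of compound 3; the two values differ in two places, so only their values can be compared. Because compound 2 gives 56800 nM, the number for compound 4 is expected to rise, and a step of an 8.6-fold higher number from compound 3 to compound 4 (0.93 log units; beyond the scatter) is estimated. Compound 4 is expected to give about 30000 nM in this assay, within 8000 nM to 100000 nM.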

Compound 4, concentration for 50% growth inhibition: 2230 nM
Compound 4: the middle estimate sits 13-fold (1.13 log units) above what was measured; measured number below the stated range.
By their numbers in this assay, from the lowest: compounds 4 and 3 (each within the scatter of the next); then compounds 1 and 2 (each within the scatter of the next).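

In this assay, taking the benzoyl group off the ring nitrogen with the hydroxy partner held fixed gives a 1.6-fold lower number from compound 3 to compound 4 (0.19 log units; within the scatter), so hydrogen and benzoyl cannot be told apart at this position, whereas (2-chlorophenyl)carbonyl does stand apart, with a 21-fold lower number from compound 1 to compound 4 (1.32 log units; beyond the scatter) as the step from that group to hydrogen. With the ring nitrogen free on both sides, a 25-fold lower number from compound 2 to compound 4 (1.41 log units; beyond the scatter) is the step for hydroxy in place of trifluoromethyl on an aromatic carbon, so the high number of compound 2 goes with its trifluoromethyl partner and not with the free ring nitrogen. Nothing in hand explains any of these steps.

Still open, as far as these compounds go, is whether an acetyl group or a longer acyl chain on the ring nitrogen would also stay level with hydrogen. Also open, from the compounds shown here alone, is how an amine or a carboxylic acid in place of hydroxy would compare with compound 4.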